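The source may hold more compounds than are shown below. What is called first, only, known or untested is meant among the compounds shown, and "the series" means these compounds.

Compounds measured so far:
- compound 1 `CC[C@H]1CN(c2ncc(-c3nnc[nH]3)cc2Cl)CCN1C1CCN(Cc2ccc(Cl)cc2F)CC1`: 6.8 nM in an assay on isolated protein for binding affinity to C-X-C chemokine receptor type 3 (Homo sapiens); a higher number here means a weaker inhibitor, a lower number a stronger inhibitor
- compound 2 `CC[C@H]1CN(c2ncc(-c3nnn[nH]3)cc2Cl)CCN1C1CCN(Cc2ccc(Cl)cc2F)CC1`: 1380 nM in this assay

Going by the values given here, compound 2 stands at the highest of the two numbers so far; its nearest neighbour is compound 1, and the one step that connects them, a 200-fold higher number from compound 1 to compound 2 (2.31 log units; beyond the scatter), is large. Compound 3 `CC[C@H]1CN(c2ncc(-c3noc(=O)[nH]3)cc2Cl)CCN1C1CCN(Cc2ccc(Cl)cc2F)CC1` is the next step from compound 2: a group of 6 heavy atoms (2 carbon, 2 nitrogen, 2 oxygen; one five-membered aromatic ring with 3 hetero atoms) in place of a group of 5 heavy atoms (1 carbon, 4 nitrogen; one five-membered aromatic ring with 4 hetero atoms), on an aromatic carbon. Among the compounds with values here, the only measured step that bears on this change is the one from compound 1 to compound 2, in which exchange of one five-membered ring for another at the same aromatic carbon moved the number a long way. Compound 3 again exchanges that ring, so a step of real size in this assay is expected rather than none, and the direction is taken as a return toward lower numbers, though this rests on a single step. For compound 3 the estimate in this assay is 200 nM, with a range from 30 nM to 1500 nM, which corresponds to an expected step of a 6.9-fold lower number from compound 2 to compound 3 (0.84 log units; beyond the scatter).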

Compound 3, half-maximal inhibitory concentration: 760 nM
For compound 3 the middle estimate is 3.8-fold (0.58 log units) below the measured one, and the stated range covers the measured number.
By their numbers in this assay, from the lowest: compound 1; then compounds 3 and 2 (each within the scatter of the next).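

In this assay the second ring exchange at this aromatic carbon gives a 1.8-fold lower number from compound 2 to compound 3 (0.26 log units; within the scatter) and so does not separate the new ring from 1H-tetrazol-5-yl. Set against the 4H-1,2,4-triazol-3-yl group, the same ring gives a 110-fold higher number from compound 1 to compound 3 (2.05 log units; beyond the scatter) and so shows that the large gap is not confined to 1H-tetrazol-5-yl: among the three compounds, only compound 1 has a low number. Nothing measured here accounts for this gap.

The compounds shown leave open whether a group outside the five-membered rings, such as a carboxylic acid or a primary amide, could come near compound 1 at 6.8 nM in this assay. They also leave open whether a methyl group on the carbon of the 4H-1,2,4-triazol-3-yl ring would keep that number.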